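Series notes: tolerance in HOS cells, compounds 1 to 3

The source may hold more compounds than are shown below. What is called first, only, known or untested is meant among the compounds shown, and "the series" means these compounds.

Measured so far:
compound 1, `Nc1c(C(=O)NCc2ccc(F)cc2F)c(=O)n(O)c2ncc(CCCOCCO)cc12`, gives > 250000 nM in an ADME assay on HOS cells (Homo sapiens) for cytotoxicity, read by luminescence and ATP content, with a stated time of 48 h; a higher number here means that more compound is tolerated, a lower number that less compound is tolerated.
compound 2, `Nc1c(C(=O)NCc2ccc(F)cc2F)c(=O)n(O)c2ncc(CCC(=O)O)cc12`, gives > 250000 nM in this assay.

For compound 1 the reading is a limit of the assay, not a number. For compound 2 the reading is likewise a limit of the assay. The step that the two limits leave unreadable from compound 1 to compound 2 therefore cannot be read. Among the measured compounds shown here, compound 2 stands at the ceiling of this assay, as does the only other compound, which the limit of > 250000 nM in this assay, at which 2 of the 2 values shown sit, records.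

Compound 3, `Nc1c(C(=O)NCc2ccc(F)cc2F)c(=O)n(O)c2ncc(/C=C/C(=O)NCCO)cc12`, is not yet measured. The change is 2-((2-hydroxyethyl)carbamoyl)ethenyl in place of 2-carboxyethyl on an aromatic carbon. For the measured compounds named here, the one measured step, a step that the two limits leave unreadable from compound 1 to compound 2, bears on it only in that it is unreadable, so no direction can be drawn from the series. With both measured compounds at the ceiling, the expectation is that compound 3 sits there too. Compound 3 is expected to give 250000 nM, between 100000 nM and 500000 nM. The expected step is a number no higher from compound 2 to compound 3 (the limit leaves the size open), nothing beyond the scatter.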

Compound 3, half-maximal cytotoxic concentration: > 250000 nM
Compound 3: no number, only a limit; the forecaster's own chance of this, stated with the estimate: 85%; the middle value lies on the limit itself.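

Compound 3 reads as a limit of this assay, as do compound 1 and compound 2, so no new step can be read between compound 3 and either of them. What stays open is whether these three compounds differ in tolerance at all, with all three held at one reading: the limit of > 250000 nM in this assay, at which 3 of the 3 values shown sit.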